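A few compounds are considered here, and "the series" means these few. Any claim that something is new, unique, unknown or untested is made for them only; others in the source may bear on it.

Measured so far in a functional assay for inhibition, with Homo sapiens as the target; on this read-out lower numbers stand for stronger inhibition and higher numbers for weaker inhibition:
compound 1 `c1ccc(Nc2nccc(-c3ccncc3)n2)cc1` gives 900 nM
compound 2 `CC(=O)Nc1cccc(Nc2nccc(-c3ccncc3)n2)c1` gives 2700 nM

Compound 1 stands lowest of the two numbers; its nearest neighbour is compound 2, and the step of a 3.0-fold higher number from compound 1 to compound 2 (0.48 log units; beyond the scatter) lies beyond the scatter. Compound 3 `CC(=O)Nc1ccc(Nc2nccc(-c3ccncc3)n2)cc1` has not yet been measured. It differs from compound 1 by acetamido in place of hydrogen on an aromatic carbon. Among the compounds with values here, the only measured step that bears on this change is the one in which the same acetamido group entered the shared core at another aromatic carbon, a 3.0-fold higher number from compound 1 to compound 2 (0.48 log units; beyond the scatter), a modest loss of inhibition. On that basis the acetamido group is expected to cost potency again, in the same direction and of a similar modest size, although nothing measured shows how this particular place behaves. Compound 3 is therefore estimated at 2200 nM, within a range from 800 nM to 6500 nM. The expected step is a 2.4-fold higher number from compound 1 to compound 3 (0.39 log units; beyond the scatter).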

Compound 3, half-maximal inhibitory concentration: 5300 nM
For compound 3 the middle estimate is 2.4-fold (0.38 log units) below the measured one; the range from low to high includes it.
By their numbers in this assay, from the lowest: compound 1; then compounds 2 and 3 (each within the scatter of the next).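

In this assay, acetamido in place of hydrogen on an aromatic carbon, para to a large group, also weakens inhibition, a 5.9-fold higher number from compound 1 to compound 3 (0.77 log units; beyond the scatter), so the loss seen earlier is not confined to one place on the ring. Compound 2 and compound 3 lie within the scatter of each other, so this read-out does not separate the two placements of the acetamido group, while compound 1, without it, remains lowest. Nothing measured here accounts for the loss at this position.

The compounds shown leave open whether the loss belongs to acetamido itself or would also follow from other groups on this carbon, such as an amine, a methoxy group or a carboxylic acid. They also leave open how a longer chain on the amide carbonyl would behave.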